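Purine benzyl chlorides: amino replacing chloro on the core

This account rests on a few compounds, and the source may have more. Where it says the series, first, only, none or still open, it means among the compounds named here.

Compound 1 `ClCc1cccc(Cn2cnc3ncnc(Cl)c32)c1`, compound 2 `ClCc1cccc(Cn2cnc3c(Cl)ncnc32)c1` and compound 3 `ClCc1cccc(Cn2cnc3c(Cl)nc(Cl)nc32)c1` share a core carrying a benzyl group that bears a chloromethyl substituent. In a functional assay on OVCAR-5 cells (Homo sapiens) for cytotoxicity, read by sulforhodamine B assay, with a stated time of 48 h (a higher number here means that more compound is tolerated, a lower number that less compound is tolerated), compound 1 gives only a limit, > 100000 nM. In this assay compound 2 gives 8910 nM, and compound 3 gives 47900 nM. Going by the values given here, compound 3 stands highest of the two numbers; its nearest neighbour is compound 2, and the step of a 5.4-fold higher number from compound 2 to compound 3 (0.73 log units; beyond the scatter) lies beyond the scatter. the limit of > 100000 nM in this assay, at which 1 of the 3 values shown sits, is where compound 1 sits, so no step to it can be counted.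

Compound 4 `Nc1nc(Cl)c2ncn(Cc3cccc(CCl)c3)c2n1` differs from compound 3 in one place: amino in place of chloro on an aromatic carbon. Among the compounds with values here, no measured step exchanges a chloro for an amino group. Within the data shown here, the only step touching the same carbon is a 5.4-fold higher number from compound 2 to compound 3 (0.73 log units; beyond the scatter), which put the chloro in place of hydrogen, and that step is of modest size. Among the measured compounds shown here, exchanging that chloro for an amino group has no precedent, and the direction is open; the estimate is therefore placed between the two numbers with a wide range. Compound 4 is expected to give 30000 nM, from 8000 nM to 100000 nM. The expected step is a 1.6-fold lower number from compound 3 to compound 4 (0.20 log units; within the scatter).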

Compound 4, concentration lethal to 50% of the cells: 57500 nM
Beside the measured number, compound 4's estimate is 1.9-fold (0.28 log units) below it; measured number inside the range.
By their numbers in this assay, from the lowest: compound 2; then compounds 3 and 4 (each within the scatter of the next). At a limit, above all of these: compound 1.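

The carbon between two ring nitrogen atoms now carries three compared groups, and in this assay the identity of the group matters less than its presence. Amino in place of chloro gives a 1.2-fold higher number from compound 3 to compound 4 (0.08 log units; within the scatter), so the two groups cannot be told apart at this position, despite the hydrogen-bond donor and acceptor that amino brings by count. Amino in place of hydrogen gives a 6.5-fold higher number from compound 2 to compound 4 (0.81 log units; beyond the scatter), the same direction as a 5.4-fold higher number from compound 2 to compound 3 (0.73 log units; beyond the scatter), so across compounds 2, 3 and 4 both substituents raise the number over hydrogen, and no compound shown goes against this; nothing measured here gives a cause for this shared rise.

Open, as far as these compounds go, is whether the rise holds for groups of another kind on this carbon, such as methoxy, a dimethylamino group or a carboxylic acid, or whether these would separate from chloro and amino. Also open is whether amino at this position behaves the same without the chloro group meta to it, since both substituted compounds shown carry that chloro.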